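Methyl on an Aromatic Carbon and Paw Edema Inhibition

The source may report more compounds than this note shows. Statements on the series, on what has been measured and on what is new or still open speak of the compounds shown alone.

In a functional assay on the whole organism for inhibition, with Rattus norvegicus as the target, read by paw edema, with a stated time of 1 h, at a dose of 100 mg/kg by the oral route (on this read-out higher numbers stand for more inhibition at the one dose given (going by the name of the read-out) and lower numbers for less inhibition), compound 2 `O=C(O)c1ccc(NC(=O)[C@@H]2CC(O)CN2S(=O)(=O)c2ccccc2)cc1` gives 24.7%, compound 1 `Cc1ccccc1S(=O)(=O)N1CC(O)C[C@H]1C(=O)Nc1ccc(C(=O)O)cc1` gives 21.2%, and compound 3 `O=C(O)c1ccc(NC(=O)[C@@H]2CCCN2S(=O)(=O)c2ccccc2)cc1` gives 26.3%. Compound 1 differs from compound 2 by methyl in place of hydrogen on an aromatic carbon, and that step was a number 3.5 percentage points lower from compound 2 to compound 1 (within the scatter). Compound 3 differs from compound 2 by hydrogen in place of hydroxy on a saturated ring carbon, and that step was a number 1.6 percentage points higher from compound 2 to compound 3 (within the scatter). Compound 4 `Cc1ccc(S(=O)(=O)N2CCC[C@H]2C(=O)Nc2ccc(C(=O)O)cc2)cc1` is not yet measured; it differs from compound 3 by methyl in place of hydrogen on an aromatic carbon. This is the same kind of change as that from compound 2 to compound 1, but not the same: there the methyl enters ortho to a large group, here para to a large group. Since compound 3 gives 26.3% and the change from compound 2 to compound 1 was a number 3.5 percentage points lower from compound 2 to compound 1 (within the scatter), compound 4 is expected to move by about a number 2.3 percentage points lower from compound 3 to compound 4 (within the scatter). The estimate for compound 4 is 24%, expected between 14% and 34%.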

Compound 4, a percentage reported as inhibition, in the whole organism at one dose (the size of the read-out at that dose, not a potency): 31.5%
Estimate against measurement, compound 4: 7.5 percentage points below; the range from low to high includes it.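

In this assay, methyl in place of hydrogen on an aromatic carbon gave a number 5.2 percentage points higher from compound 3 to compound 4 (within the scatter). Set beside the earlier case, the change shows no difference between the two cores that exceeds the scatter: the same change on two cores in this assay, a number 3.5 percentage points lower (within the scatter) from compound 2 to compound 1 and a number 5.2 percentage points higher (within the scatter) from compound 3 to compound 4, 8.7 percentage points apart, within the scatter of two such steps This does not show that the change carries over with a reliable effect, since neither step lies beyond the scatter and the methyl does not stand in the same place in the two pairs, so core and position cannot be told apart.

The compounds shown leave open what a methoxy group or an amine on the same aromatic ring would do to this read-out. They also leave open what an ester in place of the carboxylic acid would do.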